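The source may report more compounds than this note shows. Statements on the series, on what has been measured and on what is new or still open speak of the compounds shown alone.

Two sulfonamides sharing one core have been measured so far. Compound 1 `CC(C)(C)c1ccc(S(=O)(=O)Nc2cc(Cl)c(Cl)cc2N)cc1` gives 4650 nM in an assay on HEK293 cells for inhibition of 17-beta-hydroxysteroid dehydrogenase type 2 (Homo sapiens), read by scintillation counting, with a stated time of 10 min, in the presence of a further agent that is not named here; on this read-out higher numbers stand for weaker inhibition and lower numbers for stronger inhibition. Compound 2 `CC(C)(C)c1ccc(S(=O)(=O)Nc2cc(Cl)ccc2O)cc1` gives 800 nM in this assay, the lower of the two numbers, and the gap to compound 1 is beyond the usual scatter. Compound 3 `CC(C)(C)c1ccc(S(=O)(=O)Nc2cc(Cl)ccc2N)cc1` has not yet been measured; it differs from compound 2 by a single exchange, (amino in place of hydroxy on an aromatic carbon), so that an amino group takes the place of the hydroxy group on the aromatic carbon. Among the measured compounds shown here, no measured pair shows this exact exchange, so its effect can only be estimated. Compound 1 also carries an amino group at that position and gives the weaker reading, which suggests, cautiously, a shift toward weaker inhibition. For compound 3 the estimated step of a 3.1-fold higher number from compound 2 to compound 3 (0.49 log units; beyond the scatter) points that way. The expected value for compound 3 is 2500 nM, within a range from 800 nM to 8000 nM.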

Compound 3, half-maximal inhibitory concentration: 5580 nM
Beside the measured number, compound 3's estimate is 2.2-fold (0.35 log units) below it; the measured number falls inside the stated range.
By their numbers in this assay, from the lowest: compound 2; then compounds 1 and 3 (each within the scatter of the next).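

Exchanging the hydroxy group for an amino group on this aromatic carbon, ortho to a large group, now has a direct measure in this assay: a 7.0-fold higher number from compound 2 to compound 3 (0.84 log units; beyond the scatter) and so, in this pair, the hydroxy group goes with the stronger inhibition. With the amino group kept, hydrogen in place of chloro gives a 1.2-fold higher number from compound 1 to compound 3 (0.08 log units; within the scatter) and so the extra chloro group makes no readable difference in this pair. Nothing measured here explains the gap between the hydroxy and amino groups.

As far as these compounds go, it remains open whether a methoxy group, a thiol or a plain hydrogen at this position would read closer to the hydroxy group or to the amino group. From the compounds shown here alone, it is also open whether the extra chloro group would make a readable difference with the hydroxy group in place.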